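This account rests on a few compounds, and the source may have more. Where it says the series, first, only, none or still open, it means among the compounds named here.

Of the compounds shown here, three built on one shared core have so far been measured in a functional assay on WiDr cells (Homo sapiens) for inhibition; on this read-out higher numbers stand for weaker inhibition and lower numbers for stronger inhibition. Compound 1 `N#CC1CN1C(=O)Nc1ccc(F)cc1` gives 9000 nM. Compound 2 `N#CC1CN1C(=O)Nc1ccc([N+](=O)[O-])cc1` gives 3700 nM, and compound 3 `N#CC1CN1C(=O)Nc1ccc(C(F)(F)F)cc1` gives 5800 nM. Among the compounds with values here, compound 3 stands second highest of these three numbers, yet the step of a 1.6-fold lower number from compound 1 to compound 3 (0.19 log units; within the scatter) and the step of a 1.6-fold higher number from compound 2 to compound 3 (0.20 log units; within the scatter) both lie within the usual scatter, so nothing separates compound 3 from its neighbours with confidence; only the step of a 2.4-fold lower number from compound 1 to compound 2 (0.39 log units; beyond the scatter) is modest and beyond the scatter.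

Compound 4 `N#CC1CN1C(=O)Nc1ccc(S(N)(=O)=O)cc1` is not yet measured. It differs from compound 3 in one place: sulfamoyl in place of trifluoromethyl on an aromatic carbon. Within the data shown here, the steps that bear on this exchange are the ones above, all on the same aromatic carbon, and none of them moved the number far. A step of no more than the scatter is therefore expected, in either direction.

Compound 4 is expected to give about 5000 nM in this assay, estimated to fall between 2000 nM and 13000 nM. The expected step is a 1.2-fold lower number from compound 3 to compound 4 (0.06 log units; within the scatter).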

Compound 4, half-maximal inhibitory concentration: > 38000 nM
Compound 4 was reported as a limit; the forecaster's own chance of this, stated with the estimate: 5%; middle value at least 7.6-fold (0.88 log units) away from the limit.
By their numbers in this assay, from the lowest: compounds 2, 3 and 1 (each within the scatter of the next, the first and the last beyond it). At a limit, above all of these: compound 4.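

In this assay compound 4 gives > 38000 nM, which is a limit and not a number. This aromatic carbon is therefore not indifferent to what it carries, since fluoro, nitro and trifluoromethyl gave steps that were modest at most, whereas sulfamoyl gives an at least 6.5-fold higher number from compound 3 to compound 4 (0.81 log units; beyond the scatter), an at least 10-fold higher number from compound 2 to compound 4 (1.01 log units; beyond the scatter) and an at least 4.2-fold higher number from compound 1 to compound 4 (0.62 log units; beyond the scatter). Trifluoromethyl and sulfamoyl both have 4 heavy atoms, so that count does not separate them, while sulfamoyl adds hydrogen-bond donor and acceptor counts that trifluoromethyl lacks.

How far the true number of compound 4 lies from the others stays unknown because it is reported only as a limit: the limit of > 38000 nM in this assay, at which 1 of the 4 values shown sits. The compounds shown also leave open whether a methylsulfonyl group, a carboxylic acid or an amine on this carbon would behave like sulfamoyl.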